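Amide variation on the shared core: cytotoxicity notes

The source may report more compounds than this note shows. Statements on the series, on what has been measured and on what is new or still open speak of the compounds shown alone.

compound 1 `CN(Cc1ccccc1)C(=O)C1CCN(C(=O)c2ccc(S(C)(=O)=O)c([N+](=O)[O-])c2)CC1`: > 27000 nM
compound 2 `CN1CCN(C(=O)C2CCN(C(=O)c3ccc(S(C)(=O)=O)c([N+](=O)[O-])c3)CC2)CC1`: > 27000 nM

In an ADME assay on HepG2 cells (Homo sapiens) for cytotoxicity, read by CellTiter-Glo and ATP content, with a stated time of 72 h (on this read-out lower numbers stand for an effect already at smaller amounts and higher numbers for an effect only at larger amounts of compound), compound 1 gives > 27000 nM, a limit of the assay rather than a number. Compound 2 likewise gives > 27000 nM, again a limit. The step that the two limits leave unreadable from compound 1 to compound 2 is therefore unreadable. Compound 2 stands at the limit of > 27000 nM in this assay, at which 2 of the 2 values shown sit.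

Compound 3 `CC1Cc2ccccc2N1C(=O)C1CCN(C(=O)c2ccc(S(C)(=O)=O)c([N+](=O)[O-])c2)CC1` differs by 2-methyl-2,3-dihydro-1H-indol-1-yl in place of 4-methylpiperazin-1-yl on a carbonyl carbon. Only the unreadable step bears on this change, so the expected step is a step that the limit leaves unreadable from compound 2 to compound 3, none beyond the scatter. Compound 3 is expected at 30000 nM, within 15000 nM to 60000 nM, most probably reported once more as a limit.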

Compound 3, half-maximal effective concentration: > 27000 nM
Compound 3 was reported as a limit; the forecaster's own chance of this, stated with the estimate: 75%; the middle value is on the limit's open side.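

In this assay no new step can be read among compound 1, compound 2 and compound 3, since each value is a limit: the limit of > 27000 nM in this assay, at which 3 of the 3 values shown sit. The compounds shown leave open whether changing the amide group alters this read-out at all.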